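Ethoxy for Methoxy on Two Related Amine Cores

This account rests on a few compounds, and the source may have more. Where it says the series, first, only, none or still open, it means among the compounds named here.

Compound 1 `CO[C@H]1CC[C@H]2CCN(C)[C@H]2C1` and compound 2 `CCO[C@H]1CC[C@H]2CCN(C)[C@H]2C1` share one saturated core; compound 3 `CO[C@H]1CC=C2CCN(C)[C@H]2C1` and the as yet unmeasured compound 4 `CCO[C@H]1CC=C2CCN(C)[C@H]2C1` share another, and the difference between the two cores is not broken down here. In an assay on HEK293 cells for displacement of a labelled ligand from Neuronal acetylcholine receptor; alpha4/beta2 (Rattus norvegicus), with a stated time of 4 h (on this read-out lower numbers stand for stronger inhibition and higher numbers for weaker inhibition), compound 1 gives 300000 nM, and compound 2 gives 300000 nM. The change between them, (methyl in place of hydrogen on a saturated chain carbon bound to an oxygen on a saturated carbon), made no change at the digits printed from compound 1 to compound 2 (within the scatter). Compound 3 gives 3400 nM in this assay, far stronger than either. Compound 4 differs from compound 3 by methyl in place of hydrogen on a saturated chain carbon bound to an oxygen on a saturated carbon, the same change as that seen between compound 1 and compound 2. Because that earlier step was no change at the digits printed from compound 1 to compound 2 (within the scatter), compound 4 is expected to stay close to compound 3, with an expected step of a 1.2-fold higher number from compound 3 to compound 4 (0.07 log units; within the scatter). Compound 4 is therefore estimated at 4000 nM, between 1500 nM and 12000 nM.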

Compound 4, inhibition constant: 300000 nM
For compound 4 the middle estimate is 75-fold (1.88 log units) below the measured one; measured number outside the range, above it.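

In this assay, the change from methoxy to ethoxy on the core of compound 3 gives an 88-fold higher number from compound 3 to compound 4 (1.95 log units; beyond the scatter), a large weakening, whereas the same change on the core of compound 1 left the printed number as it was. The step therefore did not carry over from one core to the other: the same change on two cores in this assay, no change at the digits printed (within the scatter) from compound 1 to compound 2 and an 88-fold higher number (1.95 log units; beyond the scatter) from compound 3 to compound 4, 88-fold (1.95 log units) apart, beyond the scatter of two such steps. This shows that a flat step on one core is a poor guide to the same change on the other, but with a single pair on each core it does not show why the two differ or how other changes would transfer.

Going by these compounds, it remains open whether a longer chain such as propoxy, or a hydroxyl in place of the methoxy, would follow ethoxy on the core of compound 3. On these data alone, it is also open whether the same split between the two cores would appear in another read-out.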